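Chloro for fluoro on the amide aryl ring of compound 3

This account rests on a few compounds, and the source may have more. Where it says the series, first, only, none or still open, it means among the compounds named here.

Compound 1 `COc1ccc(C(=O)Nc2ccccc2C)cc1OC1CCCC1`: 300 nM in an assay on isolated protein for inhibition of phosphodiesterase 4A (Sus scrofa); on this read-out lower numbers stand for stronger inhibition and higher numbers for weaker inhibition
Compound 2 `COc1ccc(C(=O)Nc2ccccc2Br)cc1OC1CCCC1`: 130 nM
Compound 3 `COc1ccc(C(=O)Nc2c(F)cccc2F)cc1OC1CCCC1`: 70 nM

Compound 3 has the lowest number of the three in this assay: the gap to compound 2 is within the scatter (a 1.9-fold lower number from compound 2 to compound 3 (0.27 log units; within the scatter)), the gap to compound 1 is beyond it (a 4.3-fold lower number from compound 1 to compound 3 (0.63 log units; beyond the scatter)). Compound 4 `COc1ccc(C(=O)Nc2c(F)cccc2Cl)cc1OC1CCCC1` differs from compound 3 by chloro in place of fluoro on an aromatic carbon. Within the data shown here, two steps bear on this. One halogen-for-substituent swap at this kind of position gave a 2.3-fold lower number from compound 1 to compound 2 (0.36 log units; beyond the scatter), a modest gain. Exchanging one halogen pattern for another gave a 1.9-fold lower number from compound 2 to compound 3 (0.27 log units; within the scatter), within the scatter. Compound 4 is therefore expected to show a 1.2-fold lower number from compound 3 to compound 4 (0.07 log units; within the scatter), a step not beyond the scatter. Compound 4 is estimated at 60 nM, with a range from 25 nM to 150 nM.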

Compound 4, half-maximal inhibitory concentration: 240 nM
Beside the measured number, compound 4's estimate is 4.0-fold (0.60 log units) below it; the whole stated range lies below it.
By their numbers in this assay, from the lowest: compounds 3, 2, 4 and 1 (each within the scatter of the next, the first and the last beyond it).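

In this assay, among these compounds, this position does not treat halogens alike: chloro in place of fluoro gives a 3.4-fold higher number from compound 3 to compound 4 (0.54 log units; beyond the scatter), the only step here beyond the scatter towards a higher number. The 2-chloro-6-fluorophenyl group cannot be told apart from 2-bromophenyl, with a 1.8-fold higher number from compound 2 to compound 4 (0.27 log units; within the scatter), or from 2-methylphenyl, with a 1.3-fold lower number from compound 1 to compound 4 (0.10 log units; within the scatter), both within the scatter. Replacing 2-methylphenyl therefore brings a gain beyond the scatter with 2-bromophenyl and 2,6-difluorophenyl, but not with this mixed pattern. Nothing shown gives a reason for the step. Going by these compounds, whether 2,6-dichlorophenyl, or a methoxy group on this carbon, would resemble compound 3 or compound 4 stays open.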